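Taking the methyl off an aromatic oxygen in a cytotoxicity series

This account rests on a few compounds, and the source may have more. Where it says the series, first, only, none or still open, it means among the compounds named here.

Of the compounds shown here, three that share one core have been measured in a functional assay on MDA-MB-468 cells (Homo sapiens) for cytotoxicity, read by sulforhodamine B assay, with a stated time of 48 h, tested at 0.001 uM; on this read-out higher numbers stand for a weaker effect at the one concentration tested and lower numbers for a stronger effect. Compound 1, `COc1cc(C)cc(-c2nn(CC#N)cc2-c2ccc(-c3cccc(C(C)=O)c3)nc2)c1`, gives 83% in this assay. Compound 2, `Cc1cc(O)cc(-c2nn(CC#N)cc2-c2ccnc(-c3ccc(Oc4ccccc4)cc3)c2)c1`, gives 91%. Compound 3, `COc1cc(C)cc(-c2nn(CC#N)cc2-c2ccnc(-c3ccc(N(C)C)cc3)c2)c1`, gives 96%. The number for compound 3 is the highest of the three, but only its gap to compound 1 lies beyond the usual scatter; its gap to compound 2 lies within it, so the two cannot be told apart on this read-out.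

The next compound, compound 4, `Cc1cc(O)cc(-c2nn(CC#N)cc2-c2ccnc(-c3ccc(N(C)C)cc3)c2)c1`, is not yet measured. It differs from compound 3 in one place: hydrogen in place of methyl on an oxygen on an aromatic ring. Among the compounds with values here, the exchange is small, a single carbon leaving and no ring or hydrogen-bond group added, and no pair of measured compounds shows this exact change on its own. Compound 2 does carry the hydroxy form of the same ring and gives a value within the scatter of compound 3, which suggests the read-out is not sensitive to this position on the present evidence.

The expected step from compound 3 to compound 4 is a number 3 percentage points lower from compound 3 to compound 4 (within the scatter), none beyond the scatter. Compound 4 is therefore estimated to give 93%, likely between 82% and 100%.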

Compound 4, a percentage reported as activity, at one concentration (the size of the read-out at that concentration, not a potency): 98%
Compound 4: the middle estimate sits 5 percentage points below what was measured, and the stated range covers the measured number.
By their numbers in this assay, from the lowest: compounds 1, 2, 3 and 4 (each within the scatter of the next, the first and the last beyond it).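

In this assay, within the data shown here, the change from methoxy to hydroxy can now be read on its own, as the only difference between two compounds that otherwise match, and it comes to a number 2 percentage points higher from compound 3 to compound 4 (within the scatter) on the 3-methoxy-5-methylphenyl group. Compound 4 also gives a second clean comparison: with the hydroxy form held fixed, dimethylamino in place of phenoxy on an aromatic carbon comes to a number 7 percentage points higher from compound 2 to compound 4 (within the scatter) and so cannot be told apart from no change on this read-out either. Neither exchange moves the number beyond the scatter at the single concentration tested, and no measurement offered here gives any reason for how these numbers fall.

The compounds shown leave open what a longer chain on that oxygen, such as an ethyl group, or an amine in place of the hydroxy would do in this assay. They also leave open whether the change from methoxy to hydroxy reads the same in a compound carrying phenoxy in place of dimethylamino.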